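Triazole-Linked Cinnamic Acids: Cytotoxicity on Colon Carcinoma Cells

This account rests on a few compounds, and the source may have more. Where it says the series, first, only, none or still open, it means among the compounds named here.

Measured compounds:
compound 1 `COc1ccc(/C=C\C(=O)O)c(OCc2cn(-c3ccccc3C(=O)N3CCC(O)C3)nn2)c1CC=C(C)C`, 25400 nM
compound 2 `COc1ccc(/C=C\C(=O)O)c(OCc2cn(-c3cccc([N+](=O)[O-])c3)nn2)c1CC=C(C)C`, 6900 nM
compound 3 `COc1ccc(/C=C\C(=O)O)c(OCc2cn(-c3ccccc3C#N)nn2)c1CC=C(C)C`, 3200 nM

Of the compounds shown here, three sharing one core have been measured in a functional assay on COLO 205 cells (Homo sapiens) for cytotoxicity, read by MTT assay, with a stated time of 24 h; a higher number here means a weaker inhibitor, a lower number a stronger inhibitor. Compound 3 gives the lowest number of the three: against compound 1 the step is a 7.9-fold lower number from compound 1 to compound 3 (0.90 log units; beyond the scatter), and against compound 2 it is a 2.2-fold lower number from compound 2 to compound 3 (0.33 log units; beyond the scatter). Both steps lie beyond the scatter, so compound 3 is the strongest inhibitor among the three measured.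

Compound 4 `COc1ccc(/C=C\C(=O)O)c(OCc2cn(-c3nc4ccccc4s3)nn2)c1CC=C(C)C` is not yet measured. It differs from compound 3 in the group carried on the aromatic nitrogen: 1,3-benzothiazol-2-yl in place of 2-cyanophenyl on an aromatic nitrogen.

The two measured steps both alter the aryl group on that same nitrogen and both end at compound 3, but neither exchanges the phenyl ring for a bicyclic heteroaryl. Within the data shown here, they show that changes at this position have moved the number by modest amounts in this set, with no example of a large swing. On that basis compound 4 is expected to remain close to compound 3, with a step of a 1.1-fold higher number from compound 3 to compound 4 (0.04 log units; within the scatter) that may not reach beyond the scatter. Compound 4 is therefore estimated to give 3500 nM in this assay, within a range of 1200 nM to 10000 nM.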

Compound 4, half-maximal inhibitory concentration: 20200 nM
Compound 4: the middle estimate sits 5.8-fold (0.76 log units) below what was measured; the measured number lies above the stated range.
By their numbers in this assay, from the lowest: compound 3; then compound 2; then compounds 4 and 1 (each within the scatter of the next).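

In this assay, the exchange of a substituted phenyl for the fused 1,3-benzothiazol-2-yl on the aromatic nitrogen is a clear loss, with a 6.3-fold higher number from compound 3 to compound 4 (0.80 log units; beyond the scatter) and a 2.9-fold higher number from compound 2 to compound 4 (0.47 log units; beyond the scatter), so replacing the ring itself moves the number upward from both of these phenyl compounds. This is no general rule for phenyl groups at this position: compound 1, which also carries a phenyl ring, bearing a (3-hydroxypyrrolidin-1-yl)carbonyl group, gives a high number too, at 25400 nM, so a phenyl ring alone does not secure a low number. No measurement is available here that would explain why the 1,3-benzothiazol-2-yl group gives this result.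

The compounds shown leave open whether the loss follows from the sulfur, from the fused six-membered ring or from the removal of the phenyl ring, a question that a thiazol-2-yl group without the fused ring or a benzoxazol-2-yl group, with oxygen in place of sulfur, could help to separate. They also leave open how an unsubstituted phenyl or a phenyl bearing an amine would compare with the nitrile of compound 3.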